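Three analogues measured, a fourth to be estimated

The compounds below may be only part of what the source reports. "The series", "measured", "known", "first", "only" and "open" are said of these compounds alone.

Compound 1 `COC(=O)C1=C(C)NC(C)=C(C(=O)OC)C1c1ccccc1`, compound 2 `COC(=O)C1=C(C)N=C(C)/C(=C(\O)OC)C1c1ccccc1I` and compound 3 `COC(=O)C1=C(C)N=C(C)/C(=C(/O)OC)C1c1cccc(Cl)c1` share one core and were compared in a functional assay (muscle tissue) with Cavia porcellus as the target; on this read-out lower numbers stand for an effect already at smaller amounts and higher numbers for an effect only at larger amounts of compound. There compound 1 gives 28.2 nM, compound 2 gives 46.8 nM and compound 3 gives 15.9 nM. Compound 2 thus gives the highest of the three numbers; its gap to compound 1 lies within the usual scatter of such measurements, whereas its gap to compound 3 lies beyond it. Within the data shown here, no single-point step between measured compounds is available, so nothing is known about how a change on the aryl group alone shifts this read-out.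

Compound 4 `COC(=O)C1=C(C)N=C(C)/C(=C(\O)OC)C1c1c(Cl)cccc1Cl` has not been measured in this assay . It differs from compound 2 in one place: 2,6-dichlorophenyl in place of 2-iodophenyl on a saturated ring carbon. Because compound 2 gives 46.8 nM and the other two aryl variants fall in the same broad region, the step from compound 2 to compound 4 is expected to be modest, toward a lower number or none beyond the scatter, estimated as a 1.6-fold lower number from compound 2 to compound 4 (0.19 log units; within the scatter). Compound 4 is therefore expected to give about 30 nM, within a range from 8 nM to 110 nM.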

Compound 4, half-maximal effective concentration: 1.91 nM
Estimate against measurement, compound 4: 16-fold (1.20 log units) above; the whole stated range lies above it.
By their numbers in this assay, from the lowest: compound 4; then compounds 3, 1 and 2 (each within the scatter of the next, the first and the last beyond it).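

In this assay, the aryl group on the saturated ring carbon proves to be a place where one change moves the read-out strongly, with 2,6-dichlorophenyl in place of 2-iodophenyl giving a 25-fold lower number from compound 2 to compound 4 (1.39 log units; beyond the scatter). Among these compounds, the earlier compounds offered no single-place step, so this is the first sign that the position responds sharply to which halogens the phenyl ring carries, even though both groups have one aromatic ring of carbon only, no hydrogen-bond donors or acceptors and no net charge. Nothing available here bears on why the step is so large.

From the compounds shown here alone, the change swaps iodine for chlorine and adds a second halogen at once, so the share of each remains open. Also open, going by these compounds, is how a phenyl ring with a single chlorine, a methoxy group or an amine, or a pyridine ring in its place, would behave here.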